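The source may hold more compounds than are shown below. What is called first, only, known or untested is meant among the compounds shown, and "the series" means these compounds.

Series notes. In a functional assay on M21 cells (Homo sapiens) for antiproliferative activity, read by sulforhodamine B assay, with a stated time of 48 h (a higher number here means a weaker inhibitor, a lower number a stronger inhibitor), compound 1 `CC(=O)Nc1cccc(S(=O)(=O)Oc2ccccc2C(C)C)c1` gives 31000 nM, compound 2 `CC(C)c1ccccc1OS(=O)(=O)c1ccc(NC(=O)C(C)(C)C)cc1` gives 6200 nM and compound 3 `CC(C)(C)C(=O)Nc1ccc(S(=O)(=O)Oc2ccccc2I)cc1` gives 8300 nM. Compound 3 stands second highest of the three numbers: it cannot be separated from compound 2 within the scatter, while compound 1 sits beyond the scatter on the high side. Going by the values given here, the one single-point step measured so far, iodo in place of isopropyl on an aromatic carbon, gives a 1.3-fold higher number from compound 2 to compound 3 (0.13 log units; within the scatter).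

Compound 4 `O=C(NCC1CCCC1)Nc1ccc(S(=O)(=O)Oc2ccccc2I)cc1` is not yet measured. It differs from compound 3 by (cyclopentylmethyl)amino in place of tert-butyl on a carbonyl carbon, on the carbonyl carbon whose other neighbour is the amide-type nitrogen; the entering group brings one five-membered non-aromatic ring and one hydrogen-bond donor. Among the compounds with values here, no measured step touches this carbonyl carbon, and compounds 1 and 2 differ in more than one place, so their two values alone give no step. There is thus no basis for expecting a change beyond the scatter in this assay in either direction. The estimated step is a 1.0-fold lower number from compound 3 to compound 4 (0.02 log units; within the scatter). For compound 4 the estimate in this assay is 8000 nM, in the range 2500 nM to 25000 nM.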

Compound 4, half-maximal inhibitory concentration: 7600 nM
The estimate for compound 4 lay 1.1-fold (0.02 log units) above the measured number; low and high end bracket the measured number.
By their numbers in this assay, from the lowest: compounds 2, 4 and 3 (each within the scatter of the next); then compound 1.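

In this assay the carbonyl carbon gets its first readable step: (cyclopentylmethyl)amino in place of tert-butyl gives a 1.1-fold lower number from compound 3 to compound 4 (0.04 log units; within the scatter). This position therefore accepts a change from (tert-butyl)carbonyl to (cyclopentylmethyl)carbamoyl, which adds a five-membered non-aromatic ring and a hydrogen-bond donor, with no separation between compound 3 and compound 4 in this read-out. Nothing available explains why the number holds across this change.

Still open, going by these compounds, is whether a carboxylic acid or a longer alkyl chain on this carbonyl carbon would move the number beyond the scatter, since a single step cannot show how far the position tolerates change. Also open, on these data alone, is whether (cyclopentylmethyl)amino behaves the same way when isopropyl replaces iodo on the aromatic carbon.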